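A few compounds are considered here, and "the series" means these few. Any claim that something is new, unique, unknown or untested is made for them only; others in the source may bear on it.

Measured compounds:
compound 1 `O=C(Nc1cccc(/C=C/C(=O)c2nc3ccccc3[nH]2)c1)c1cccc(Br)c1` gives 1560 nM
compound 2 `COc1ccc(C(=O)Nc2cccc(/C=C/C(=O)c3nc4ccccc4[nH]3)c2)cc1` gives 4880 nM
compound 3 `Cc1ccccc1S(=O)(=O)Nc1cccc(/C=C/C(=O)c2nc3ccccc3[nH]2)c1` gives 955 nM

In a functional assay on HCT-116 cells (Homo sapiens) for antiproliferative activity, read by MTT assay, with a stated time of 48 h (a higher number here means a weaker inhibitor, a lower number a stronger inhibitor), compound 3 holds the lowest number of the three: the gap to compound 1 is within the scatter, as a 1.6-fold lower number from compound 1 to compound 3 (0.21 log units; within the scatter) shows, while a 5.1-fold lower number from compound 2 to compound 3 (0.71 log units; beyond the scatter) is modest and beyond it. Compound 4 `Cc1ccc(S(=O)(=O)Nc2cccc(/C=C/C(=O)c3nc4ccccc4[nH]3)c2)cc1C` differs from compound 3 by 3,4-dimethylphenyl in place of 2-methylphenyl on a sulfonyl sulfur. Going by the values given here, no measured step touches only the sulfonyl-bound aryl; the closest guide is a 3.1-fold higher number from compound 1 to compound 2 (0.50 log units; beyond the scatter), a modest shift on changing the aryl substituent pattern on the carbonyl side. Moving methyl groups within the sulfonyl-bound ring is therefore expected to give a step within the scatter, direction unknown, as a 1.0-fold higher number from compound 3 to compound 4 (0.02 log units; within the scatter). Compound 4 is estimated at 1000 nM, range 400 nM to 2500 nM.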

Compound 4, half-maximal inhibitory concentration: 2230 nM
Compound 4: the middle estimate sits 2.2-fold (0.35 log units) below what was measured; measured number inside the range.
By their numbers in this assay, from the lowest: compounds 3, 1 and 4 (each within the scatter of the next, the first and the last beyond it); then compound 2.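

Going by these compounds alone, the sulfonyl-bound aryl is not a silent position in this assay: 3,4-dimethylphenyl in place of 2-methylphenyl on a sulfonyl sulfur gives a 2.3-fold higher number from compound 3 to compound 4 (0.37 log units; beyond the scatter), the first step that touches only this ring. The sulfonamide link stays the same, so the substitution on the aryl alone is enough to shift the number beyond the scatter. Nothing at hand accounts for this step.

Still open, as far as these compounds go, is how a plain phenyl, or an amine or a carboxylic acid on this ring, would read. Also open, from the compounds shown here alone, is whether the same substitution pattern would shift the number on the carbonyl side.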